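Aryl swap on the ring nitrogen: notes toward compound 4

The source may hold more compounds than are shown below. What is called first, only, known or untested is meant among the compounds shown, and "the series" means these compounds.

Measured so far:
compound 1 `C=CCc1ccc(OCc2cn(-c3ccccc3CO)nn2)c(O)c1` — a functional assay on HL-60 cells (Homo sapiens) for inhibition, read by MTT assay, with a stated time of 72 h, tested at 50 uM; a lower number here means less inhibition of growth, a higher number more inhibition of growth at the concentration tested: 47.1%
compound 2 `C=CCc1cc(O)c(O)c(CN2CCC(CO)CC2)c1` — this assay : 43.3%
compound 3 `C=CCc1cc(O)c(O)c(CN2CCC(CCO)CC2)c1` — this assay : 52.1%

All three numbers lie within the scatter of one another; compound 1 sits between compound 2 and compound 3 on the numbers alone. For the measured compounds named here, the only measured step, a number 8.8 percentage points higher from compound 2 to compound 3 (within the scatter), concerns the saturated side chain of a different core and does not bear on the change studied here.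

Compound 4 `C=CCc1ccc(OCc2cn(-c3ccc(Br)cc3)nn2)c(O)c1` differs from compound 1 in one place: 4-bromophenyl in place of 2-(hydroxymethyl)phenyl on an aromatic nitrogen. Going by the values given here, no measured step on this core probes a change on the aromatic nitrogen, so nothing points to a shift beyond the scatter.

Compound 4 is therefore expected to give about 47% in this assay, within 32% to 62%, meaning an expected step of a number 0.1 percentage points lower from compound 1 to compound 4 (within the scatter).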

Compound 4, percent growth inhibition at one concentration: 25.6%
Estimate against measurement, compound 4: 21.4 percentage points above; the measured number lies below the stated range.
By their numbers in this assay, from the lowest: compound 4; then compounds 2, 1 and 3 (each within the scatter of the next).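

For the compounds shown here, on the shared core, the group on the aromatic nitrogen is the one place so far where a single change moves the number in this assay beyond the scatter: a number 21.5 percentage points lower from compound 1 to compound 4 (beyond the scatter). This position is therefore not indifferent to the group it carries, and 4-bromophenyl does not stand in for 2-(hydroxymethyl)phenyl here. Nothing measured accounts for this step.

Open, as far as these compounds go, is whether the step follows the loss of hydroxymethyl or the arrival of bromine, as the change does both at once. Plain phenyl, or aminomethyl or a carboxylic acid in place of the hydroxymethyl, would bear on that.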